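Shortening the selenocyanate arm on the methoxyphenyl amine

The source may hold more compounds than are shown below. What is called first, only, known or untested is meant among the compounds shown, and "the series" means these compounds.

Within the data shown here, compound 2 `COc1ccc(N(C)c2nc(C)nc3ccccc23)cc1OCCCCC[Se]C#N` holds the highest number of the two measured so far in a functional assay on MDA-MB-231 cells (Homo sapiens) for inhibition, read by MTT assay, with a stated time of 48 h; a lower number here means a stronger inhibitor, a higher number a weaker inhibitor: compound 2 gives 4410 nM, while compound 1 `C[Se]c1ccc(N(C)c2nc(C3CC3)nc3ccccc23)cc1` gives 18 nM, a gap well beyond the scatter. Among the measured compounds shown here, compound 1 and compound 2 differ in several places, so no single-change step can be drawn from them; their two values are all that is known.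

Compound 3 `COc1ccc(N(C)c2nc(C)nc3ccccc23)cc1C[Se]C#N` has not yet been measured in this assay. It differs from compound 2 by a group of 4 heavy atoms (2 carbon, 1 nitrogen, 1 selenium; no ring) in place of a group of 9 heavy atoms (6 carbon, 1 nitrogen, 1 oxygen, 1 selenium; no ring), on an aromatic carbon, the change sitting on an aromatic carbon ortho to a methoxy group. For the measured compounds named here, with no measured step of one change to guide it, a moderate lowering beyond the scatter is expected, a 2.9-fold lower number from compound 2 to compound 3 (0.47 log units; beyond the scatter), because compound 1 with its shorter selenium group gives 18 nM. Compound 3 is therefore expected to give about 1500 nM in this assay, with a range from 300 nM to 8000 nM.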

Compound 3, half-maximal inhibitory concentration: 153 nM
The estimate for compound 3 lay 9.8-fold (0.99 log units) above the measured number; measured number below the stated range.
By their numbers in this assay, from the lowest: compound 1; then compound 3; then compound 2.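

In this assay, the aromatic carbon ortho to a methoxy group emerges as a sensitive position: a group of 4 heavy atoms (2 carbon, 1 nitrogen, 1 selenium; no ring) in place of a group of 9 heavy atoms (6 carbon, 1 nitrogen, 1 oxygen, 1 selenium; no ring) gives a 29-fold lower number from compound 2 to compound 3 (1.46 log units; beyond the scatter) in a single change. Among these compounds, this is the first one-place step, and the smaller group carries the lower number. Nothing on hand accounts for the size of this step.

The step removes the oxygen and shortens the chain together, so the compounds shown cannot separate these two changes. Open too, as far as these compounds go, is how a chain of intermediate length, or a thiocyanate in place of the selenium-bearing group, would read at this position.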